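The source may hold more compounds than are shown below. What is called first, only, known or untested is meant among the compounds shown, and "the series" means these compounds.

In an assay on CHO cells for displacement of a labelled ligand from adenosine receptor A3 (Homo sapiens), read by scintillation counting, with a stated time of 45 min, tested at 1 uM, in the presence of a further agent that is not named here (on this read-out lower numbers stand for less inhibition and higher numbers for more inhibition at the one concentration tested (going by the name of the read-out)), compound 1 `CCCn1c(=O)c2[nH]c(-c3ccc(S(=O)(=O)N4CCN(c5ccc(Cl)cc5)CC4)cc3)nc2n(CC)c1=O` gives 28%. Compound 2 `CCCn1c(=O)[nH]c2nc(-c3ccc(S(=O)(=O)N4CCN(c5cccc(Br)c5)CC4)cc3)[nH]c2c1=O` gives 27% and compound 3 `CCCn1c(=O)[nH]c2nc(-c3ccc(S(=O)(=O)N4CCN(Cc5ccc(Br)cc5)CC4)cc3)[nH]c2c1=O` gives 28%. Within the data shown here, the one measured step, a number 1 percentage points higher from compound 2 to compound 3 (within the scatter), changes the group on the amine nitrogen in the ring and leaves the read-out where it was. Compound 1 sits level with compound 3 at the digits shown and a single point from compound 2, so the three numbers are indistinguishable within the scatter and no compound can be set above another.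

Compound 4 `CCCn1c(=O)c2[nH]c(-c3ccc(S(=O)(=O)N4CCN(c5ccc(Cl)cc5)CC4)cc3)nc2n(C)c1=O` differs from compound 1 only at the chain on the aromatic nitrogen: hydrogen in place of methyl on a saturated chain carbon bound to an aromatic nitrogen. Among the measured compounds shown here, no measured step touches this chain; the step from compound 2 to compound 3 concerns a different part of the molecule and bears on it only in showing that the inhibition stayed flat under one change. With nothing to point either way, the inhibition of compound 4 is expected to stay close to that of compound 1, a step of a number 2 percentage points lower from compound 1 to compound 4 (within the scatter) that would be within the scatter. Compound 4 is therefore estimated at 26%, with a range from 12% to 40%.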

Compound 4, a percentage reported as inhibition, at one concentration (the size of the read-out at that concentration, not a potency): 39%
Beside the measured number, compound 4's estimate is 13 percentage points below it, and the stated range covers the measured number.
By their numbers in this assay, from the lowest: compounds 2, 1 and 3 (each within the scatter of the next); then compound 4.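

In this assay, among these compounds, the chain on the aromatic nitrogen is the first place where the read-out moves: going from ethyl to methyl gives a number 11 percentage points higher from compound 1 to compound 4 (beyond the scatter). Among the compounds shown here, the only earlier step, a number 1 percentage points higher from compound 2 to compound 3 (within the scatter), changed the group on the ring amine nitrogen and stayed flat, so the shift at this chain is new, though modest and resting on a single pair. Nothing available explains the difference.

The compounds shown leave open whether the read-out keeps following chain length at this position, for instance with a longer chain such as butyl, or how a terminal hydroxyl or carboxylic acid on the chain would read. Also open, going by these compounds, is whether the same change gives a similar step when the group on the ring amine nitrogen is different.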